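Succinimide-piperazine amides: chloro removal and chain methylation

The compounds below may be only part of what the source reports. "The series", "measured", "known", "first", "only" and "open" are said of these compounds alone.

Compound 3 `CC(C(=O)N1CCN(c2cccc(Cl)c2)CC1)N1C(=O)CCC1=O` gives 75% in a functional assay on the whole organism (strain Swiss) with Mus musculus as the target, in the maximal electroshock model, with a stated time of 0.5 h, at a dose of 100 mg/kg by the intraperitoneal route (a lower number here means a weaker effect, a higher number a stronger effect of the compound at the dose given), the highest number of the three measured compounds. Compound 2 `CCC(C(=O)N1CCN(c2cccc(Cl)c2)CC1)N1C(=O)CCC1=O` gives 50% in this assay, and compound 1 `CC(C(=O)N1CCN(c2ccccc2)CC1)N1C(=O)CCC1=O` gives 0%. The cores of compound 3 and compound 2 differ by methyl in place of hydrogen on a saturated chain carbon, two bonds along the chain from an amide-type nitrogen in a ring and a carbonyl carbon, a change that made the step of a number 25 percentage points higher from compound 2 to compound 3 (beyond the scatter). Within the chloro-bearing series, compound 3 and compound 1 differ by hydrogen in place of chloro on an aromatic carbon, and that change made the step of a number 75 percentage points lower from compound 3 to compound 1 (beyond the scatter), the largest in the set.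

Compound 4 `CCC(C(=O)N1CCN(c2ccccc2)CC1)N1C(=O)CCC1=O` has not been measured in this assay. It differs from compound 2 by hydrogen in place of chloro on an aromatic carbon, the same kind of change as from compound 3 to compound 1, with the place described in the same words. Among the compounds with values here, only one example of this change is available, so the expectation rests on a single step. The step from compound 2 to compound 4 is expected to be a number 45 percentage points lower from compound 2 to compound 4 (beyond the scatter), close to the earlier one, because a number 75 percentage points lower from compound 3 to compound 1 (beyond the scatter) removed nearly all activity once the chloro group was gone. Compound 4 is therefore estimated at 5%, between 0% and 25%.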

Compound 4, a percentage reported as activity, at one dose (the size of the read-out at that dose, not a potency): 25%
The estimate for compound 4 lay 20 percentage points below the measured number; the measured number falls inside the stated range.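

Hydrogen in place of chloro lowers the number on both cores, and on the core of compound 2 it gives a number 25 percentage points lower from compound 2 to compound 4 (beyond the scatter), so the direction carries over but the size does not in this assay: the same change on two cores in this assay, a number 75 percentage points lower (beyond the scatter) from compound 3 to compound 1 and a number 25 percentage points lower (beyond the scatter) from compound 2 to compound 4, 50 percentage points apart, beyond the scatter of two such steps

Methyl in place of hydrogen on the saturated chain carbon gives a number 25 percentage points higher from compound 1 to compound 4 (beyond the scatter) among the phenyl compounds, whereas among the 3-chlorophenyl compounds the number is higher with hydrogen at that carbon, so this change does not carry over even in direction: the same change on two cores in this assay, a number 25 percentage points higher (beyond the scatter) from compound 2 to compound 3 and a number 25 percentage points lower (beyond the scatter) from compound 4 to compound 1, 50 percentage points apart, beyond the scatter of two such steps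

These two pairs show that each change depends on the group at the other place, but they rest on four compounds at one dose and do not show why the steps differ or how either change would behave on a further core.

On these data alone, it remains open whether fluoro, methoxy or trifluoromethyl in place of chloro would follow the 3-chlorophenyl compounds or the phenyl compounds. As far as these compounds go, a longer chain such as propyl on the saturated chain carbon is also open, as is how its step would depend on the aromatic group.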